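The source may report more compounds than this note shows. Statements on the series, on what has been measured and on what is new or still open speak of the compounds shown alone.

Working notes on the series. In a functional assay on P388 cells (Mus musculus) for antiproliferative activity, with a stated time of 72 h (a lower number here means a stronger inhibitor, a higher number a weaker inhibitor), compound 2 `CSc1cnc2ccccc2c1[Se]CC#CCO` gives 2.6 ug/mL, the second highest of the three numbers in hand. Its nearest neighbour is compound 3 `CSc1cnc2ccccc2c1[Se]CC#CCOC(=O)c1ccccc1` at 3.5 ug/mL, reached by a 1.3-fold higher number from compound 2 to compound 3 (0.13 log units; within the scatter), benzoyl in place of hydrogen on an oxygen on a saturated carbon. The furthest is compound 1 `C#CCSc1cnc2ccccc2c1[Se]CC#CCCl` at 0.8 ug/mL, a difference beyond the scatter; compound 1 differs from compound 2 in two places at once, so its number is not a step that can be read on its own.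

Compound 4 `CSc1cnc2ccccc2c1[Se]CC#CCCl` has not yet been measured in this assay. Relative to compound 2 the change is chloro in place of hydroxy on a saturated chain carbon bound to a triple-bonded carbon. For the measured compounds named here, no measured step covers this exchange. The step from compound 2 to compound 3 touches the same oxygen but replaces its hydrogen rather than the hydroxy itself, and was within the scatter. Compound 1 carries the chloro terminus yet also a different group on sulfur, so its lower number cannot be assigned to the chloro alone. The expectation is therefore a modest move toward a lower number, at most a 1.7-fold lower number from compound 2 to compound 4 (0.24 log units; within the scatter), and it may well stay within the scatter. Compound 4 is estimated at 1.5 ug/mL, with a range of 0.6 ug/mL to 4 ug/mL.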

Compound 4, concentration for 50% inhibition: 0.4 ug/mL
For compound 4 the middle estimate is 3.8-fold (0.57 log units) above the measured one, and the stated range ends above it.
By their numbers in this assay, from the lowest: compounds 4 and 1 (each within the scatter of the next); then compounds 2 and 3 (each within the scatter of the next).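

For the compounds shown here, the exchange of hydroxy for chloro on a saturated chain carbon bound to a triple-bonded carbon is the first single change to give a step beyond the scatter in this assay (a 6.5-fold lower number from compound 2 to compound 4 (0.81 log units; beyond the scatter)), whereas benzoyl on the oxygen of the same terminus did not (a 1.3-fold higher number from compound 2 to compound 3 (0.13 log units; within the scatter)). The terminus therefore matters in this assay in a way the hydroxy and benzoate pair could not show, and the number of compound 1 can now be read, since the group on sulfur makes no change beyond the scatter when the chloro terminus is kept (a 2.0-fold lower number from compound 1 to compound 4 (0.30 log units; within the scatter)). Nothing at hand explains the size of the hydroxy to chloro step.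

On these data alone, whether the low number is particular to chloro remains open, as bromo, methoxy or an amine on the same carbon would be needed to tell. Also open, as far as these compounds go, is whether the ethynyl on the sulfur chain stays without effect when the terminus carries hydroxy, and whether a longer chain in place of 4-chlorobut-2-yn-1-yl keeps the number.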